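Amide variation on a shared core: cytotoxicity notes

The source may report more compounds than this note shows. Statements on the series, on what has been measured and on what is new or still open speak of the compounds shown alone.

The series keeps one core throughout; compound 1 is `C=CCCC(=O)Nc1cc2nc(C3CCCCC3)[nH]c2cc1Oc1ccc(F)cc1` and compound 2 is `O=C(Nc1cc2nc(C3CCCCC3)[nH]c2cc1Oc1ccc(F)cc1)c1ccc(F)cc1F`. In an ADME assay on Vero cells (Chlorocebus sabaeus) for cytotoxicity, read by MTT assay, with a stated time of 2 days (on this read-out lower numbers stand for stronger inhibition and higher numbers for weaker inhibition), compound 1 gives > 200000 nM, which is a limit of the assay and not a number. In this assay compound 2 gives > 200000 nM, again a limit rather than a measured number. Among the measured compounds shown here, the single step between measured compounds, a step that the two limits leave unreadable from compound 1 to compound 2, therefore cannot be read in size or direction. What the two measured values show is summarised by the limit of > 200000 nM in this assay, at which 2 of the 2 values shown sit. Compound 3 is `Cc1ccc(C(=O)Nc2cc3nc(C4CCCCC4)[nH]c3cc2Oc2ccc(F)cc2)cc1`, still to be measured in this assay. Its change from compound 2 is 4-methylphenyl in place of 2,4-difluorophenyl on a carbonyl carbon. For the measured compounds named here, no measured step bears on this change in a readable way, since the only step in hand is hidden by the limits on both sides. With both measured compounds at the limit, the expectation for compound 3 is that it also reaches the limit, with no step beyond the scatter. The expected step is a number no higher from compound 2 to compound 3 (the limit leaves the size open). For compound 3 the estimate in this assay is 200000 nM, within 100000 nM to 400000 nM.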

Compound 3, half-maximal inhibitory concentration: 26000 nM
The estimate for compound 3 lay 7.7-fold (0.89 log units) above the measured number; measured number outside the range, below it.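

In this assay, the group on the carbonyl carbon can move the read-out: 4-methylphenyl in place of 2,4-difluorophenyl gives an at least 7.6-fold lower number from compound 2 to compound 3 (0.88 log units; beyond the scatter). The same group in place of but-3-en-1-yl gives an at least 7.6-fold lower number from compound 1 to compound 3 (0.88 log units; beyond the scatter), so the change registers against both an aromatic and an open-chain partner on the shared core. Compound 3 is the only compound here with a readable number, which shows that a change at this one place is enough to bring cytotoxicity within the range of the assay, while the other compounds remain at a limit and not at a number: the limit of > 200000 nM in this assay, at which 2 of the 3 values shown sit.

The change from compound 2 to compound 3 removes the two fluorines and adds the methyl group in one step, and the compounds shown do not separate these two parts; plain phenyl or 4-fluorophenyl on the carbonyl carbon would bear directly on that question. Also open, on these data alone, are the full sizes of both steps, and how a ring carrying an amine or a carboxylic acid, or a longer chain on the carbonyl carbon, would read.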